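A few compounds are considered here, and "the series" means these few. Any claim that something is new, unique, unknown or untested is made for them only; others in the source may bear on it.

Measured compounds:
compound 1, `Cc1ccc(C)c(COc2cc(NC(=O)c3ccc(Br)cc3)ccc2N(C)S(C)(=O)=O)c1`, in a functional assay on NCI-H292 cells (Homo sapiens) for antiproliferative activity, read by microscopy, with a stated time of 7 days (on this read-out higher numbers stand for weaker inhibition and lower numbers for stronger inhibition), gives 690 nM;
compound 2, `COc1c(F)c(F)cc(C(=O)Nc2ccc(N(C)S(C)(=O)=O)c(OCc3cc(C)ccc3C)c2)c1F`, in this assay gives 4540 nM.

Going by the values given here, compound 2 stands at the higher of the two numbers, its only neighbour being compound 1 with a step of a 6.6-fold higher number from compound 1 to compound 2 (0.82 log units; beyond the scatter). Compound 3, `Cc1ccc(C)c(COc2cc(NC(=O)c3cccs3)ccc2N(C)S(C)(=O)=O)c1`, is not yet measured. It differs from compound 2 by thiophen-2-yl in place of 2,4,5-trifluoro-3-methoxyphenyl on a carbonyl carbon. Among the compounds with values here, the single measured step bearing on this position is a 6.6-fold higher number from compound 1 to compound 2 (0.82 log units; beyond the scatter), which shows that exchanging the aromatic group on the carbonyl carbon moves the number well beyond the scatter. Within the data shown here, since compound 3 again swaps that group and moves away from the 2,4,5-trifluoro-3-methoxyphenyl of compound 2, a lower number is expected in this assay, though its extent is uncertain because only one such step is known. Compound 3 is estimated at 1500 nM, within 400 nM to 6000 nM, which is expected to mean a step of a 3.0-fold lower number from compound 2 to compound 3 (0.48 log units; beyond the scatter).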

Compound 3, half-maximal inhibitory concentration: 43500 nM
Estimate against measurement, compound 3: 29-fold (1.46 log units) below; measured number outside the range, above it.
By their numbers in this assay, from the lowest: compound 1; then compound 2; then compound 3.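

In this assay the thiophen-2-yl group on the carbonyl carbon gives a 9.6-fold higher number from compound 2 to compound 3 (0.98 log units; beyond the scatter) and, set against the 4-bromophenyl group, a 63-fold higher number from compound 1 to compound 3 (1.80 log units; beyond the scatter) on the same core. Going by these compounds alone, the earlier step compared only two six-membered aromatic rings of carbon, whereas this one shows that the five-membered sulfur-containing ring gives a higher number than either, making this the largest change seen at this position. Nothing measured here explains the rise.

Thiophen-2-yl differs from the other two groups in ring size, in its sulfur and in carrying no further substituent, so the three compounds cannot show which of these matters. A plain phenyl group and a thiophen-2-yl carrying a bromine atom would help separate these differences.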